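Compound 3: swapping the group at the chain end

The source may hold more compounds than are shown below. What is called first, only, known or untested is meant among the compounds shown, and "the series" means these compounds.

In a functional assay, read by spectrophotometry, tested at 100 uM (a higher number here means a weaker inhibitor, a lower number a stronger inhibitor), the measured compounds are:
Compound 1 `O=C(/C=C/c1ccccc1)c1cccc(NC(=O)c2cc(-c3ccncc3)n[nH]2)c1` gives 71500 nM
Compound 2 `CN(C)c1ccc(/C=C/C(=O)c2cccc(NC(=O)c3cc(-c4ccncc4)n[nH]3)c2)cc1` gives 60900 nM

Compound 2 sits within the scatter of compound 1 (step a 1.2-fold lower number from compound 1 to compound 2 (0.07 log units; within the scatter)), so neither ranks ahead. Compound 3 `O=C(/C=C/c1ccco1)c1cccc(NC(=O)c2cc(-c3ccncc3)n[nH]2)c1` changes one group (furan-2-yl in place of 4-(dimethylamino)phenyl on a double-bonded chain carbon bound to a double-bonded chain carbon), with furan-2-yl in place of 4-(dimethylamino)phenyl on a double-bonded chain carbon bound to a double-bonded chain carbon. Among the compounds with values here, the only measured step (dimethylamino in place of hydrogen, a 1.2-fold lower number from compound 1 to compound 2 (0.07 log units; within the scatter)) altered the leaving group without a change beyond the scatter. Within the data shown here, no measured compound carries furan-2-yl, so no step beyond the scatter is expected in this assay, and no direction can be favoured. The expected step is small (a 1.1-fold higher number from compound 2 to compound 3 (0.06 log units; within the scatter)). Compound 3 is estimated at 70000 nM (range 35000 nM to 130000 nM).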

Compound 3, half-maximal inhibitory concentration: 72300 nM
Compound 3: the middle estimate sits 1.0-fold (0.01 log units) below what was measured; low and high end bracket the measured number.
By their numbers in this assay, from the lowest: compounds 2, 1 and 3 (each within the scatter of the next).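

In this assay, the ring at the chain end can now be a five-membered aromatic ring with a hetero atom, not only a six-membered carbon ring. Furan-2-yl gives a 1.2-fold higher number from compound 2 to compound 3 (0.07 log units; within the scatter) when it replaces 4-(dimethylamino)phenyl, and a 1.0-fold higher number from compound 1 to compound 3 (0.00 log units; within the scatter) when it replaces phenyl, so all three groups read alike at this place. Nothing measured here accounts for this sameness. Still open, going by these compounds, is whether a group without an aromatic ring at this place, such as an amine, a carboxylic acid or a longer carbon chain, would give a step beyond the scatter.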